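This account rests on a few compounds, and the source may have more. Where it says the series, first, only, none or still open, it means among the compounds named here.

Measured compounds in an assay on HEK293 cells for agonist activity at transient receptor potential cation channel subfamily M member 8 (Homo sapiens), read by fluorescence and calcium flux, with a stated time of 15 min; a higher number here means that more compound is needed for the effect, a lower number that less compound is needed:
compound 1 `CCN(Cc1ccoc1)C(=O)COc1ccc(C)cc1`: 136 nM
compound 2 `CCN(Cc1ccco1)C(=O)COc1ccc(C)cc1`: 489 nM
compound 3 `CCCc1ccc(OCC(=O)N(CC)Cc2cccs2)cc1`: 1810 nM

Compound 2 stands second highest of the three numbers in this assay. Among the measured compounds shown here, its nearest neighbour is compound 1, separated by the step of a 3.6-fold higher number from compound 1 to compound 2 (0.56 log units; beyond the scatter); compound 3 lies further off with the highest number, and no single-change step connects it to compound 2.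

Compound 4 `CCN(Cc1cn[nH]c1)C(=O)COc1ccc(C)cc1` differs from compound 2 as follows: 1H-pyrazol-4-yl in place of furan-2-yl on a saturated chain carbon bound to an amide-type nitrogen

For the measured compounds named here, the only measured step that bears on this change is the swap of one five-membered aromatic ring for another at the same place, a 3.6-fold higher number from compound 1 to compound 2 (0.56 log units; beyond the scatter), modest and beyond the scatter. Going by the values given here, no measured step introduces a hydrogen-bond donor at this position, so the direction is uncertain; a step of comparable size, in either direction, or none beyond the scatter, is expected in this assay. Compound 4 is estimated at 700 nM, range 200 nM to 2500 nM, which is expected to mean a 1.4-fold higher number from compound 2 to compound 4 (0.16 log units; within the scatter).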

Compound 4, half-maximal effective concentration: "active" (no number reported)
Compound 4: no number reported; there is nothing to compare the estimate with.
By their numbers in this assay, from the lowest: compound 1; then compound 2; then compound 3.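

Among the compounds shown here, compound 4 is reported only as active, without a number, so no step from compound 2 to compound 4 can be read. From the compounds shown here alone, it remains open how 1H-pyrazol-4-yl in place of furan-2-yl shifts the number, and no evidence here bears on that result.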